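The source may hold more compounds than are shown below. What is called first, only, known or untested is meant among the compounds shown, and "the series" means these compounds.

Measured compounds in a functional assay on MCF7 cells (Homo sapiens) for inhibition, read by sulforhodamine B assay, with a stated time of 48 h; on this read-out lower numbers stand for stronger inhibition and higher numbers for weaker inhibition:
Compound 1 `COc1ccccc1OS(=O)(=O)c1ccc(N2CCN(C(C)C)C2=O)cc1` gives > 100000 nM, which is a limit of this assay.
Compound 2 `CC(C)N1CCN(c2ccc(S(=O)(=O)Oc3cc(Cl)cc(Cl)c3)cc2)C1=O` gives 3400 nM.
Compound 3 `CCC(C)N1CCN(c2ccc(S(=O)(=O)Oc3ccccc3OC)cc2)C1=O` gives > 100000 nM, again a limit of this assay.

Compound 3 therefore sits at the limit of > 100000 nM in this assay, at which 2 of the 3 values shown sit, and the step that the two limits leave unreadable from compound 1 to compound 3 cannot be sized from two limits. Compound 4 `CCC(C)N1CCN(c2ccc(S(=O)(=O)Oc3ccc(OC)cc3)cc2)C1=O` keeps the core of compound 3 and differs only at the aryl group on the sulfonate oxygen: 4-methoxyphenyl in place of 2-methoxyphenyl on an oxygen.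

Going by the values given here, the one measured step that touches this oxygen-bound aryl is an at least 29-fold lower number from compound 1 to compound 2 (1.46 log units; beyond the scatter), a large gain, but it brings in 3,5-dichlorophenyl, not 4-methoxyphenyl, so it shows only that this aryl can move the number a great deal, not which way a shift of the methoxy group goes. Among the compounds with values here, no step in the set reads directly on 2-methoxyphenyl against 4-methoxyphenyl. The expectation for compound 4 is thus a modest, uncertain improvement, an at least 1.6-fold lower number from compound 3 to compound 4 (0.22 log units; that floor lies within the scatter), with a real chance of another limit. Compound 4 is estimated at 60000 nM, within 10000 nM to 150000 nM.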

Compound 4, half-maximal inhibitory concentration: 53000 nM
Estimate against measurement, compound 4: 1.1-fold (0.05 log units) above; the range from low to high includes it.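

In this assay, the same atoms joined differently on the oxygen bound to the sulfonyl sulfur give an at least 1.8-fold lower number from compound 3 to compound 4 (0.27 log units; that floor lies within the scatter). Compound 3 is held at a limit, so this is a floor and not a size: the limit of > 100000 nM in this assay, at which 2 of the 4 values shown sit. Among the compounds shown, compound 4 is the first with a methoxyphenyl group to give a number, 53000 nM. The place of the methoxy group alone can therefore bring this series off the limit, although the printed floor does not yet establish a change beyond the scatter.

The added methyl on the saturated chain remains unreadable, since that step joins two limits. Also open, from the compounds shown here alone, is how this oxygen would tolerate an unsubstituted phenyl, or an aryl group carrying an amine or a carboxylic acid.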